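Removing a Methoxy Group: Cytotoxicity in Three Diaryl Compounds

The source may hold more compounds than are shown below. What is called first, only, known or untested is meant among the compounds shown, and "the series" means these compounds.

The study examines how a cytotoxicity read-out shifts when one methoxy group is taken off an aromatic ring. In an ADME assay on RAW264.7 cells (Mus musculus) for cytotoxicity, read by MTT assay, with a stated time of 24 h, tested at 10 ug/mL (on this read-out lower numbers stand for a stronger effect and higher numbers for a weaker effect at the one concentration tested), compound 1 `COc1ccc(CCC(=O)c2cccc(O)c2)cc1` gives 86.3% and compound 2 `COc1ccc(CCC(=O)c2cccc(O)c2)c(OC)c1` gives 74.8%. The two differ in a single place, described as hydrogen in place of methoxy on an aromatic carbon. The resulting step, a number 11.5 percentage points higher from compound 2 to compound 1 (beyond the scatter), lies beyond the scatter. Compound 3 `COc1ccc(CCCc2ccc(OC)c(OC)c2OC)c(O)c1` gives 36.7% in this assay, the lowest of the three numbers; the difference between the cores of compound 2 and compound 3 is not broken down here.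

Compound 4 `COc1ccc(CCCc2cccc(OC)c2OC)c(O)c1` has not yet been measured. It differs from compound 3 as hydrogen in place of methoxy on an aromatic carbon, the same kind of change as that from compound 2 to compound 1, though the surroundings differ: in compound 3 the place is ortho to a methoxy group, meta to a methoxy group and para to a large group, whereas in compound 2 it is ortho to a large group and meta to a methoxy group. Resting on the step from compound 2 to compound 1, a number 11.5 percentage points higher from compound 2 to compound 1 (beyond the scatter), the expected step is a number 10.3 percentage points higher from compound 3 to compound 4 (beyond the scatter). Compound 4 is therefore estimated at 47%, between 33% and 62%.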

Compound 4, a percentage reported as activity, at one concentration (the size of the read-out at that concentration, not a potency): 63%
For compound 4 the middle estimate is 16 percentage points below the measured one; measured number outside the range, above it.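

In this assay, the same replacement of methoxy by hydrogen on the core of compound 3 gives a number 26.3 percentage points higher from compound 3 to compound 4 (beyond the scatter), so the number rises on both cores shown. The direction of the change therefore carries over from one core to the other, but its size does not: the same change on two cores in this assay, a number 11.5 percentage points higher (beyond the scatter) from compound 2 to compound 1 and a number 26.3 percentage points higher (beyond the scatter) from compound 3 to compound 4, 14.8 percentage points apart, beyond the scatter of two such steps. Two pairs cannot show whether the gap between the steps follows from the cores themselves, from the different surroundings of the place changed, or from the different starting numbers, so neither step can be taken as a reliable measure for a further core in this series.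

The compounds shown leave open what happens when the methoxy group gives way to something other than hydrogen, such as a fluorine atom, an amine or a carboxylic acid. They also leave open whether a longer chain linking the two aromatic rings would change the size of the step.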